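Cytotoxicity of a methoxy-to-methyl swap on a shared core

The source may report more compounds than this note shows. Statements on the series, on what has been measured and on what is new or still open speak of the compounds shown alone.

Compound 1 `COC(=O)c1ccc(NCc2cncn2Cc2cccc(OC)c2)cc1-c1ccccc1` is tested in a toxicity assay on NIH3T3 cells (Mus musculus) for cytotoxicity, read by resazurin assay; on this read-out lower numbers stand for an effect already at smaller amounts and higher numbers for an effect only at larger amounts of compound; for compound 1 the result reads "not determined" (no result reported), so no single number anchors it. In this assay compound 2 `c1ccc(-c2ccc(Cn3cncc3CNc3ccc(-c4ccc[nH]4)c(-c4ccccc4)c3)cc2)cc1` gives only a limit, > 10000 nM. This is the limit of > 10000 nM in this assay, at which 1 of the 2 values shown sits. Compound 3 `COC(=O)c1ccc(NCc2cncn2Cc2ccc(C)cc2)cc1-c1ccccc1` differs from compound 1 by 4-methylphenyl in place of 3-methoxyphenyl on a saturated chain carbon bound to an aromatic nitrogen. For the measured compounds named here, with no measured step between compounds, any shift in this assay from compound 1 to compound 3 is expected to stay within the usual scatter, in no set direction. Compound 3 is estimated at 20000 nM, with a range from 6000 nM to 80000 nM.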

Compound 3, half-maximal effective concentration: 50000 nM
Compound 3: middle estimate off by 2.5-fold (0.40 log units), on the low side; low and high end bracket the measured number.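

For the compounds shown here, compound 1 carries no single number here in this assay, so no step from it to compound 3 can be read. The compounds shown leave open whether 3-methoxybenzyl and 4-methylbenzyl on the shared core give different results.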